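A few compounds are considered here, and "the series" means these few. Any claim that something is new, unique, unknown or untested is made for them only; others in the source may bear on it.

Measured so far in an ADME assay on L6 cells (Rattus norvegicus) for cytotoxicity; a higher number here means a weaker inhibitor, a lower number a stronger inhibitor:

compound 1, `N=C(N)c1ccc(-c2cc3cc(C(=N)N)ccc3o2)cc1`: 1900 nM
compound 2, `N=C(N)c1ccc(-c2cc3ccc(C(=N)N)cc3o2)cc1`: 800 nM
compound 3, `COc1cc(C(=N)N)ccc1-c1cc2cc(C(=N)N)ccc2o1`: 157000 nM

Compound 1 and compound 2 are made of the same atoms joined differently; the difference between the two cores is not broken down here. In this assay compound 2 gives the lowest of the three numbers, compound 1 standing nearest to it and compound 3 furthest. Within the data shown here, the one counted change in the set is methoxy in place of hydrogen on an aromatic carbon, and it produced an 83-fold higher number from compound 1 to compound 3 (1.92 log units; beyond the scatter).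

Compound 4, `COc1cc(C(=N)N)ccc1-c1cc2ccc(C(=N)N)cc2o1`, is still to be measured in this assay. It relates to compound 2 as compound 3 relates to compound 1: methoxy in place of hydrogen on an aromatic carbon. The surroundings of the place are described in the same words in both cases, so this is the same change, occurring twice among the compounds shown. Among the measured compounds shown here, on that basis the step is expected to be large, with the estimate a 56-fold higher number from compound 2 to compound 4 (1.75 log units; beyond the scatter); this rests on an 83-fold higher number from compound 1 to compound 3 (1.92 log units; beyond the scatter), the only prior instance, so the size is uncertain. Compound 4 is thus expected near 45000 nM, within a range from 8000 nM to 200000 nM.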

Compound 4, half-maximal inhibitory concentration: 108000 nM
Compound 4: middle estimate off by 2.4-fold (0.38 log units), on the low side, within the range that was stated.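

In this assay, methoxy in place of hydrogen on an aromatic carbon gives a 140-fold higher number from compound 2 to compound 4 (2.13 log units; beyond the scatter), a large step in the same direction as the one already seen on the other core. These two pairs show neither why the number rises nor whether a step of this size would hold on a core outside these compounds or in any read-out beyond this assay. Within the series shown, the change carries from one core to the other with its direction kept and its size agreeing within the scatter: the same change on two cores in this assay, an 83-fold higher number (1.92 log units; beyond the scatter) from compound 1 to compound 3 and a 140-fold higher number (2.13 log units; beyond the scatter) from compound 2 to compound 4, 1.6-fold (0.21 log units) apart, within the scatter of two such steps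

The compounds shown leave open whether a hydroxyl, an ethoxy or an amine in the same place would give a step of similar size, or whether the large step is particular to methoxy. They also leave open whether methoxy on another carbon of the same six-membered aromatic ring would behave in the same way on either core.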